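The compounds below may be only part of what the source reports. "The series", "measured", "known", "first", "only" and "open" are said of these compounds alone.

Both compounds below were measured in a functional assay on the whole organism for positive allosteric modulation, with Mus musculus as the target (a lower number here means that less compound is needed, a higher number that more compound is needed for the effect), and give these doses:

- compound 1 `CCC(=O)N(c1ccc(F)c(Cl)c1)C1CCCC1N(C)C` with 0.7 mg/kg as its dose
- compound 2 `CCC(=O)N(c1ccc(Cl)c(Cl)c1)C1CCCC1N(CC)CC` with 0.3 mg/kg as its dose

Compound 2 has the lower number of the two, so less of it is needed for the effect, and its gap to compound 1 lies beyond the usual scatter. Compound 3 `C=CCN(C)C1CCCC1N(C(=O)CC)c1ccc(Cl)c(Cl)c1` keeps the core of compound 2 and changes one group: it carries allyl(methyl)amino in place of diethylamino on a saturated ring carbon, and allyl(methyl)amino in place of diethylamino on a saturated ring carbon gives the count of that swap. For the measured compounds named here, no measured pair differs in one place only, so the data offer no direct guide to this change. The expectation is therefore modest: a slight rise in the number, with no step beyond the scatter, and a 1.3-fold higher number from compound 2 to compound 3 (0.12 log units; within the scatter) is the estimated size of it. The estimated value for compound 3 is 0.4 mg/kg with an expected range from 0.15 mg/kg to 1 mg/kg in this assay.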

Compound 3, dose for half-maximal effect: 6 mg/kg
Beside the measured number, compound 3's estimate is 15-fold (1.18 log units) below it; measured number outside the range, above it.
By their numbers in this assay, from the lowest: compound 2; then compound 1; then compound 3.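

In this assay, this position proves highly sensitive to the amine it carries: allyl(methyl)amino in place of diethylamino on a saturated ring carbon gives a 20-fold higher number from compound 2 to compound 3 (1.30 log units; beyond the scatter), a large loss for a single change. The two groups have equal counts of heavy atoms and hydrogen-bond acceptors, so those counts alone do not predict the dose needed here; the entering group differs by containing a double bond outside aromatic rings. No measurement shown explains the size of this step.

From the compounds shown here alone, it remains open whether the step follows from replacing one ethyl with methyl or the other with allyl. Ethyl(methyl)amino on the core of compound 2 would help separate those two parts of the change, while propyl(methyl)amino would test the saturated counterpart of allyl(methyl)amino.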